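Swapping the aryl group on the ring nitrogen

The source may report more compounds than this note shows. Statements on the series, on what has been measured and on what is new or still open speak of the compounds shown alone.

Of the compounds shown here, three sharing one core have been tested in a functional assay on A549 cells (Homo sapiens) for antiproliferative activity, read by MTT assay, with a stated time of 48 h; on this read-out higher numbers stand for weaker inhibition and lower numbers for stronger inhibition. Compound 1 `N#CC1=C(N)Oc2c(c3nc4ccccc4nc3c3ccccc23)C12C(=O)N(Cc1cnnn1-c1ccc(S(N)(=O)=O)cc1)c1ccccc12` reaches only the limit of the assay, > 50000 nM. Compound 2 `CCc1ccccc1-n1nncc1CN1C(=O)C2(C(C#N)=C(N)Oc3c(N)cc4nc5ccccc5nc4c32)c2ccccc21` gives a measurable though weak value of 24600 nM. Compound 3 `CCOc1ccccc1-n1nncc1CN1C(=O)C2(C(C#N)=C(N)Oc3c(N)cc4nc5ccccc5nc4c32)c2ccccc21` also reaches only the assay limit, > 50000 nM. Compound 3 therefore stands at the boundary of what this assay reports, with no number of its own. The step of an at least 2.0-fold higher number from compound 2 to compound 3 (0.30 log units; that floor lies within the scatter) describes its relation to compound 2, and the limit of > 50000 nM in this assay, at which 2 of the 3 values shown sit, shows how common this outcome is among the three values.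

Compound 4 `N#CC1=C(N)Oc2c(N)cc3nc4ccccc4nc3c2C12C(=O)N(Cc1cnnn1-c1ccc(F)c(Cl)c1)c1ccccc12` differs from compound 3 in one place: 3-chloro-4-fluorophenyl in place of 2-ethoxyphenyl on an aromatic nitrogen. For the measured compounds named here, the only measured step that changes this aryl group, an at least 2.0-fold higher number from compound 2 to compound 3 (0.30 log units; that floor lies within the scatter), ends at the limit, so no firm direction can be read from it. Compound 4 is expected to remain a weak inhibitor, with an estimate of 45000 nM spanning 15000 nM to 150000 nM. The step of an at least 1.1-fold lower number from compound 3 to compound 4 (0.04 log units; that floor lies within the scatter) is expected to lie within the scatter.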

Compound 4, half-maximal inhibitory concentration: 43400 nM
Compound 4: middle estimate off by 1.0-fold (0.02 log units), on the high side; the measured number falls inside the stated range.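

Compound 4 adds a second measured value at this position, and the halogen-bearing ring can be set beside the ethyl-bearing one. Putting 3-chloro-4-fluorophenyl in place of 2-ethylphenyl gives a 1.8-fold higher number from compound 2 to compound 4 (0.25 log units; within the scatter), so this assay does not tell these two groups apart, and both compounds remain weak inhibitors. Compound 3 has only a limit, so an at least 1.1-fold lower number from compound 3 to compound 4 (0.06 log units; that floor lies within the scatter) gives a floor and no true size, because that end of the step rests on a limit and not on a number: the limit of > 50000 nM in this assay, at which 2 of the 4 values shown sit.

Going by these compounds, whether an amine or a carboxylic acid on this aryl ring would move the value beyond the scatter remains open. So does the question of whether a plain alkyl chain in place of the ring on the nitrogen would change the value at all.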